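The compounds below may be only part of what the source reports. "The series", "measured", "known", "first", "only" and "open" are said of these compounds alone.

Of the compounds shown here, two of one series have been tested in a functional assay on CHO cells for antagonist activity at prostaglandin E2 receptor EP4 subtype (Homo sapiens), read by calcium flux, with a stated time of 15 min; a lower number here means a stronger inhibitor, a higher number a weaker inhibitor. Compound 1, `CCCc1c(C(=O)N[C@@H](C)c2ccc(C(=O)O)cc2)nnn1Cc1ccc(C(F)(F)F)cc1`, gives only a limit of the assay rather than a number: in this assay compound 1 reads > 10000 nM. Among the compounds with values here, compound 2, `C[C@H](NC(=O)c1c(-c2ccccc2)nnn1Cc1ccccc1)c1ccc(C(=O)O)cc1`, gives a number in this assay, namely 647 nM, and it is the only number available, with the limit of > 10000 nM in this assay, at which 1 of the 2 values shown sits, as the other entry.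

Compound 3, `COc1ccc(Cn2nnc(-c3ccccc3)c2C(=O)N[C@@H](C)c2ccc(C(=O)O)cc2)cc1OC`, is not yet measured. It differs from compound 2 in one respect: 3,4-dimethoxyphenyl in place of phenyl on a saturated chain carbon bound to an aromatic nitrogen. Within the data shown here, no measured pair of compounds isolates this change, so the effect of the two methoxy groups on the benzyl group is not known from the data.

The step from compound 2 to compound 3 is expected to be small, a 1.3-fold lower number from compound 2 to compound 3 (0.11 log units; within the scatter), within or just beyond the usual scatter, and in this assay compound 3 is expected to give about 500 nM, in a range from 150 nM to 2000 nM.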

Compound 3, half-maximal inhibitory concentration: 119 nM
Compound 3: the middle estimate sits 4.2-fold (0.62 log units) above what was measured; the whole stated range lies above it.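

Within the data shown here, the earlier compounds offered no measured pair that isolated this position, and this is the first step to do so: in this assay, the change from benzyl to 3,4-dimethoxybenzyl gives a 5.4-fold lower number from compound 2 to compound 3 (0.74 log units; beyond the scatter). The position therefore responds to substitution on this aromatic ring, and adding the two methoxy groups, with the heavier group of the pair entering, lowers the number rather than raising it. Nothing measured here accounts for the size of this step.

As far as these compounds go, it remains open whether a single methoxy group would give the same step, or whether an ethoxy group or a chlorine atom would serve in place of the methoxy groups. From the compounds shown here alone, the step is also known only with the phenyl group of the shared core, so its size with a propyl chain there, as in compound 1, is unknown.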